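The source may hold more compounds than are shown below. What is called first, only, known or untested is meant among the compounds shown, and "the series" means these compounds.

In an ADME assay on MT4 cells (Homo sapiens) for cytotoxicity, read by MTT assay, with a stated time of 96 h (a higher number here means that more compound is tolerated, a lower number that less compound is tolerated), compound 1 `NS(=O)(=O)c1ccc(N2N=C(c3ccc(Oc4ccccc4)cc3)CC2c2ccccc2)cc1` gives 42000 nM, compound 2 `Cc1cccc(C2CC(c3ccc(Oc4ccccc4)cc3)=NN2c2ccc(S(N)(=O)=O)cc2)c1` gives 35000 nM and compound 3 `Cc1cccc(C2CC(c3ccccc3)=NN2c2ccc(S(N)(=O)=O)cc2)c1` gives 37000 nM. Compound 2 thus stands within the scatter of both other compounds, and the three numbers cannot be told apart. Compound 4 `Cc1ccc(C2CC(c3ccc(Oc4ccccc4)cc3)=NN2c2ccc(S(N)(=O)=O)cc2)cc1` has the same atoms as compound 2, joined differently: 4-methylphenyl in place of 3-methylphenyl on a saturated ring carbon. It carries 4-methylphenyl in place of 3-methylphenyl on a saturated ring carbon.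

Among the measured compounds shown here, two measured steps bear on this change, though only indirectly, as no measured pair moves the methyl. Placing methyl on an aromatic carbon gave a 1.2-fold lower number from compound 1 to compound 2 (0.08 log units; within the scatter). Replacing phenoxy with hydrogen on an aromatic carbon gave a 1.1-fold higher number from compound 2 to compound 3 (0.02 log units; within the scatter). Since neither step went beyond the scatter, no step beyond the scatter is expected in this assay for the present change. The expected step is a 1.1-fold higher number from compound 2 to compound 4 (0.02 log units; within the scatter). Compound 4 is estimated at 37000 nM, with an expected range of 22000 nM to 60000 nM.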

Compound 4, half-maximal cytotoxic concentration: 7200 nM
Compound 4: the middle estimate sits 5.1-fold (0.71 log units) above what was measured, outside the stated range (below it).
By their numbers in this assay, from the lowest: compound 4; then compounds 2, 3 and 1 (each within the scatter of the next).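

In this assay the change to 4-methylphenyl from 3-methylphenyl on the saturated ring carbon gives a 4.9-fold lower number from compound 2 to compound 4 (0.69 log units; beyond the scatter) even though the two compounds have the same atoms, so at this position the place of the methyl on the phenyl group matters. Methyl on the phenyl group is therefore not without consequence in this assay: the earlier step to the 3-methylphenyl compound stayed within the scatter, whereas 4-methylphenyl gives a 5.8-fold lower number from compound 1 to compound 4 (0.77 log units; beyond the scatter) and lies beyond it. Nothing measured here accounts for this difference.

As far as these compounds go, it remains open whether the lower number is particular to methyl or would also appear with 4-ethylphenyl, 4-methoxyphenyl or 4-chlorophenyl on the same saturated ring carbon. From the compounds shown here alone, it also remains open whether 4-methylphenyl has the same effect on the core of compound 3, which lacks the phenoxy group.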